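Moving the chlorine on the dichlorophenyl group of compound 3

The source may report more compounds than this note shows. Statements on the series, on what has been measured and on what is new or still open speak of the compounds shown alone.

Values in a functional assay on HeLa cells (Homo sapiens) for cytotoxicity, read by MTT assay, with a stated time of 24 h; on this read-out lower numbers stand for stronger inhibition and higher numbers for weaker inhibition:
compound 1 `CN1C/C(=C\c2ccc(F)cc2)C(=O)/C(=C/c2cccc([N+](=O)[O-])c2)C1` gives 6250 nM
compound 2 `CN1C/C(=C\c2ccc(Br)cc2)C(=O)/C(=C/c2cccc([N+](=O)[O-])c2)C1` gives 11900 nM
compound 3 `CN1C/C(=C\c2cccc([N+](=O)[O-])c2)C(=O)/C(=C/c2ccc(Cl)cc2Cl)C1` gives 8900 nM

Compound 3 at 8900 nM lies within the scatter of both other compounds, so the three values set no order. The next compound, compound 4 `CN1C/C(=C\c2cccc([N+](=O)[O-])c2)C(=O)/C(=C/c2ccc(Cl)c(Cl)c2)C1`, has the same atoms joined differently, with 3,4-dichlorophenyl in place of 2,4-dichlorophenyl on a double-bonded chain carbon bound to a double-bonded ring carbon.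

The nearest evidence comes from changes at that same place, a 1.4-fold higher number from compound 1 to compound 3 (0.15 log units; within the scatter) and a 1.3-fold lower number from compound 2 to compound 3 (0.13 log units; within the scatter), both within the scatter. The halogen swap on the aromatic carbon, a 1.9-fold higher number from compound 1 to compound 2 (0.28 log units; within the scatter), also stays within it. Among the measured compounds shown here, no measured pair compares these two dichlorophenyl groups directly, so this evidence is indirect. With those steps so small, no change beyond the scatter is expected in this assay, and the expected step is a 1.0-fold lower number from compound 3 to compound 4 (0.02 log units; within the scatter). Compound 4 is estimated at 8500 nM, with an expected range of 4000 nM to 18000 nM.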

Compound 4, half-maximal inhibitory concentration: 9120 nM
Beside the measured number, compound 4's estimate is 1.1-fold (0.03 log units) below it; the measured number falls inside the stated range.
By their numbers in this assay, from the lowest: compounds 1, 3, 4 and 2 (each within the scatter of the next).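

Read directly for the first time, the two dichlorophenyl groups give a 1.0-fold higher number from compound 3 to compound 4 (0.01 log units; within the scatter) in this assay and cannot be told apart at this place. The 3,4-dichlorophenyl group is also unresolved from the two single-halogen phenyl groups, with a 1.3-fold lower number from compound 2 to compound 4 (0.12 log units; within the scatter) and a 1.5-fold higher number from compound 1 to compound 4 (0.16 log units; within the scatter) in this assay, so all four groups at this place form one set within the scatter. Nothing measured on these compounds bears on the reason for this result.

Whether any group on this double-bonded chain carbon can move the number beyond the scatter stays open, since all four shown are halogenated phenyl groups and none carries an amine, a carboxylic acid or a longer chain. From the compounds shown here alone, the nitrophenyl group stays the same throughout, so what a change there would do also remains open.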